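Trading a methyl for a trifluoromethyl on a tolerated scaffold

The compounds below may be only part of what the source reports. "The series", "measured", "known", "first", "only" and "open" are said of these compounds alone.

Of the compounds shown here, two built on the same core have been tested so far in an ADME assay on Huh-7 cells (Homo sapiens) for cytotoxicity, with a stated time of 3 days; a higher number here means that more compound is tolerated, a lower number that less compound is tolerated. Compound 1 `O=C(Nc1cccc(C(F)(F)F)c1)c1c(NO)cc(-c2ccccc2)oc1=O` gives 19000 nM in this assay. Compound 2 `Cc1cccc(NC(=O)c2c(NO)cc(-c3cccs3)oc2=O)c1` reaches only a limit of this assay, > 20000 nM, so its exact value is not known. This places compound 2 at the limit of > 20000 nM in this assay, at which 1 of the 2 values shown sits, the top edge of the numbers seen so far. Compound 3 `O=C(Nc1cccc(C(F)(F)F)c1)c1c(NO)cc(-c2cccs2)oc1=O` has not been measured yet. It differs from compound 2 in one place: trifluoromethyl in place of methyl on an aromatic carbon. Among the measured compounds shown here, no pair of measured compounds isolates this change, so no measured step can be borrowed. Compound 1 also carries a trifluoromethyl group and gives 19000 nM, near the top edge of the numbers seen so far. The step of a number no higher from compound 2 to compound 3 (the limit leaves the size open) is expected to be small, within the usual scatter. Compound 3 is therefore estimated at 20000 nM, with a likely range from 10000 nM to 40000 nM.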

Compound 3, half-maximal cytotoxic concentration: 11000 nM
Compound 3: middle estimate off by 1.8-fold (0.26 log units), on the high side; the measured number falls inside the stated range.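

In this assay, trifluoromethyl in place of methyl on the six-membered aromatic ring now has its first reading, an at least 1.8-fold lower number from compound 2 to compound 3 (0.25 log units; that floor lies within the scatter), which gives only a floor for the step and does not separate the two compounds. Compound 2 stands at a limit of the assay, so the full size of this step stays unknown: the limit of > 20000 nM in this assay, at which 1 of the 3 values shown sits.

With trifluoromethyl held in place, the other change on the shared core gives a 1.7-fold lower number from compound 1 to compound 3 (0.24 log units; within the scatter), so this swap of rings also stays inside the usual spread of repeated measurements.

The compounds shown leave open how the number responds to other groups at this place on the ring, such as a chlorine atom, a methoxy group or an amine. They also leave open what methyl does when paired with phenyl on the same core.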